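This account rests on a few compounds, and the source may have more. Where it says the series, first, only, none or still open, it means among the compounds named here.

Measured compounds:
compound 1 `O=C(N[C@@H](CCc1ccccc1)CNc1ccc(OC(F)(F)F)cc1)[C@@H](CC(=O)N1CCOCC1)CC1CCCCC1` – 18 nM
compound 2 `CC(C)[C@@H](CNc1ccc(OC(F)(F)F)cc1)NC(=O)[C@@H](CC(=O)N1CCOCC1)CC1CCCCC1` – 11 nM

Among the measured compounds shown here, in an assay on isolated protein for inhibition of cathepsin S (Homo sapiens) (on this read-out higher numbers stand for weaker inhibition and lower numbers for stronger inhibition), compound 2 gives 11 nM, and the one measured step, a 1.6-fold lower number from compound 1 to compound 2 (0.21 log units; within the scatter), falls within the scatter, so compound 2 and compound 1 cannot be told apart on these numbers. Compound 3 `CS(=O)(=O)CC[C@@H](CNc1ccc(OC(F)(F)F)cc1)NC(=O)[C@@H](CC(=O)N1CCOCC1)CC1CCCCC1` differs from compound 2 by 2-(methylsulfonyl)ethyl in place of isopropyl on a saturated chain carbon bound to an amide-type nitrogen and a saturated chain carbon. For the measured compounds named here, no measured step brings in a sulfonyl-bearing chain; the only step known, the one of compound 1 to compound 2, is small. Compound 3 is therefore expected to stay close to compound 2, a step of a 1.4-fold higher number from compound 2 to compound 3 (0.13 log units; within the scatter) and no shift beyond the scatter. The estimate for compound 3 in this assay is 15 nM, within 4 nM to 60 nM.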

Compound 3, inhibition constant: 5 nM
For compound 3 the middle estimate is 3.0-fold (0.48 log units) above the measured one; measured number inside the range.
By their numbers in this assay, from the lowest: compound 3; then compounds 2 and 1 (each within the scatter of the next).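

In this assay, the position on a saturated chain carbon bound to an amide-type nitrogen and a saturated chain carbon now shows steps beyond the scatter: 2-(methylsulfonyl)ethyl in place of isopropyl gives a 2.2-fold lower number from compound 2 to compound 3 (0.34 log units; beyond the scatter), and methylsulfonyl in place of phenyl gives a 3.6-fold lower number from compound 1 to compound 3 (0.56 log units; beyond the scatter), both modest. The earlier pair could not be told apart, so this position does respond to the group it carries. Nothing measured here bears on what lies behind these steps. From the compounds shown here alone, it remains open whether the sulfonyl or the chain itself carries the change, and how a plain butyl chain, an amine or a carboxylic acid would read at this position.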